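A few compounds are considered here, and "the series" means these few. Any claim that something is new, unique, unknown or untested is made for them only; others in the source may bear on it.

Measured compounds:
compound 1 `CC(C)N(C)c1sc(C(=O)c2ccc(Cl)s2)c(N)c1C#N` gives 1420 nM
compound 2 `CCNc1sc(C(=O)c2ccc(Cl)s2)c(N)c1C#N` gives 222 nM
compound 3 `C=CCNc1sc(C(=O)c2ccc(Cl)s2)c(N)c1C#N` gives 638 nM

In an assay for inhibition of Maternal embryonic leucine zipper kinase (Homo sapiens), read by ADP-Glo, with a stated time of 0.5 h (on this read-out higher numbers stand for weaker inhibition and lower numbers for stronger inhibition), compound 3 stands second highest of the three numbers, with a 2.2-fold lower number from compound 1 to compound 3 (0.35 log units; beyond the scatter) on one side and a 2.9-fold higher number from compound 2 to compound 3 (0.46 log units; beyond the scatter) on the other. Compound 4 `N#Cc1c(Nc2ccccc2F)sc(C(=O)c2ccc(Cl)s2)c1N` carries 2-fluorophenyl in place of allyl on a nitrogen on an aromatic ring. Among the compounds with values here, no measured step exchanges an alkyl group on that nitrogen for an aromatic ring; the steps of a 6.4-fold lower number from compound 1 to compound 2 (0.81 log units; beyond the scatter) and a 2.9-fold higher number from compound 2 to compound 3 (0.46 log units; beyond the scatter) show only that, among the three alkylamino groups, ethylamino gives the lowest number. They do not bear directly on the change to compound 4, so no direction beyond the scatter is expected; the estimated step is a 1.4-fold higher number from compound 3 to compound 4 (0.15 log units; within the scatter). For compound 4 the expected value is 900 nM, with a range of 250 nM to 3500 nM.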

Compound 4, half-maximal inhibitory concentration: 707 nM
Beside the measured number, compound 4's estimate is 1.3-fold (0.10 log units) above it; the measured number falls inside the stated range.
By their numbers in this assay, from the lowest: compound 2; then compounds 3, 4 and 1 (each within the scatter of the next, the first and the last beyond it).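

In this assay, an aromatic ring on this nitrogen gives a number that cannot be told apart from the allyl compound (a 1.1-fold higher number from compound 3 to compound 4 (0.04 log units; within the scatter)), so the series tolerates 2-fluorophenyl here as well as alkyl groups. The ring does not match ethyl (a 3.2-fold higher number from compound 2 to compound 4 (0.50 log units; beyond the scatter)), and its step from isopropyl(methyl)amino stays within the scatter (a 2.0-fold lower number from compound 1 to compound 4 (0.30 log units; within the scatter)). No available evidence accounts for these steps.

Open, on these data alone, is whether phenyl without the fluorine would differ from 2-fluorophenyl. Also open, as far as these compounds go, is how a propyl chain or a methyl group on this nitrogen would compare with ethyl in compound 2.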